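Triazolyl-methyl substituent survey on a spirooxindole core

The source may hold more compounds than are shown below. What is called first, only, known or untested is meant among the compounds shown, and "the series" means these compounds.

Measured compounds, a functional assay on HepG2 cells (Homo sapiens) for antiproliferative activity, read by MTT assay, with a stated time of 48 h; a higher number here means a weaker inhibitor, a lower number a stronger inhibitor:
- compound 1 `Cc1cccc(-n2nncc2CN2C(=O)C3(C(C#N)=C(N)Oc4c(N)cc5nc6ccccc6nc5c43)c3ccccc32)c1`: > 50000 nM (a limit of the assay, not a number)
- compound 2 `N#CC1=C(N)Oc2c(N)cc3nc4ccccc4nc3c2C12C(=O)N(Cc1cnnn1-c1ccc(Cl)cc1)c1ccccc12`: > 50000 nM (a limit of the assay, not a number)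
- compound 3 `CC(=O)Nc1ccc(-n2nncc2CN2C(=O)C3(C(C#N)=C(N)Oc4c(N)cc5nc6ccccc6nc5c43)c3ccccc32)cc1`: > 50000 nM (a limit of the assay, not a number)

Compound 3 stands at a limit in this assay, and the two other values shown are limits as well, so no ordering among the three is readable. The steps a step that the two limits leave unreadable from compound 1 to compound 2, a step that the two limits leave unreadable from compound 1 to compound 3 and a step that the two limits leave unreadable from compound 2 to compound 3 therefore carry no readable size; what unites them is the limit of > 50000 nM in this assay, at which 3 of the 3 values shown sit.

Compound 4 `N#CC1=C(N)Oc2c(N)cc3nc4ccccc4nc3c2C12C(=O)N(Cc1cnnn1-c1c(F)cccc1F)c1ccccc12` differs from compound 3 in one place: 2,6-difluorophenyl in place of 4-acetamidophenyl on an aromatic nitrogen. All three measured steps bear on it, since each swaps the group on the same aromatic nitrogen, and none of them moved any compound off the limit. No step beyond the scatter is therefore expected in this assay, and the most likely outcome for compound 4 is again a limit. The step from compound 3 to compound 4 is expected to be a step that the limit leaves unreadable from compound 3 to compound 4. Compound 4 is estimated at 60000 nM, within 20000 nM to 200000 nM.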

Compound 4, half-maximal inhibitory concentration: > 50000 nM
Compound 4: no number, only a limit; the forecaster's own chance of this, stated with the estimate: 85%; the middle value lies beyond the limit too.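

Compound 4 gives only a limit in this assay, so no step from compound 1, compound 2 or compound 3 to compound 4 can be read: the limit of > 50000 nM in this assay, at which 4 of the 4 values shown sit.

The compounds shown leave open whether any group on this aromatic nitrogen, or any change elsewhere on the shared core, gives a readable value in this assay.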